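The source may hold more compounds than are shown below. What is called first, only, known or untested is meant among the compounds shown, and "the series" means these compounds.

Compound 2 `NC(=S)N/N=C/c1ccc2ccccc2n1` and compound 1 `S=C(N/N=C/c1ccc2ccccc2n1)Nc1cccc(Br)c1` share one core and differ only at an amide-type nitrogen. In a functional assay on SGC-7901 cells (Homo sapiens) for antiproliferative activity, read by sulforhodamine B assay, with a stated time of 72 h (a lower number here means a stronger inhibitor, a higher number a weaker inhibitor), compound 1 gives 78600 nM, while compound 2 gives 32700 nM. Compound 2 therefore stands at the lower of the two numbers, and the step of a 2.4-fold lower number from compound 1 to compound 2 (0.38 log units; beyond the scatter) shows how much the number fell when the 3-bromophenyl group was taken off that nitrogen. Compound 3 `Cc1ccccc1NC(=S)N/N=C/c1ccc2ccccc2n1` is not yet measured; it carries 2-methylphenyl in place of hydrogen on an amide-type nitrogen. For the measured compounds named here, this change runs the opposite way to the one measured step: an aromatic ring is put back onto the same nitrogen, now a 2-methylphenyl in place of the earlier 3-bromophenyl. Going by the values given here, only the step from compound 1 to compound 2 bears on it, and that step was modest. The expectation for compound 3 is therefore a modest rise in number, meaning a somewhat weaker inhibitor than compound 2, because a 2.4-fold lower number from compound 1 to compound 2 (0.38 log units; beyond the scatter) went the other way when the ring was removed. Compound 3 is estimated at 65000 nM, within a range from 25000 nM to 160000 nM, which corresponds to an expected step of a 2.0-fold higher number from compound 2 to compound 3 (0.30 log units; within the scatter).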

Compound 3, half-maximal inhibitory concentration: > 100000 nM
Compound 3: only a limit was reported (the forecaster's own chance of this, stated with the estimate: 10%); middle value at least 1.5-fold (0.18 log units) from the limit.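

In this assay compound 3 gives > 100000 nM, which is a limit of the assay and not a number, so each step to it is only a floor: the limit of > 100000 nM in this assay, at which 1 of the 3 values shown sits. Even so, placing 2-methylphenyl on the nitrogen that carries hydrogen in compound 2 gives an at least 3.0-fold higher number from compound 2 to compound 3 (0.48 log units; beyond the scatter), which makes this the second aromatic ring on this nitrogen to go with a higher number than hydrogen, and none of the three compounds goes against that. Exchanging one ring for the other gives an at least 1.2-fold higher number from compound 1 to compound 3 (0.10 log units; that floor lies within the scatter), so the 2-methylphenyl and 3-bromophenyl groups cannot be ranked against each other from these results.

The compounds shown leave open whether a plain phenyl ring would already raise the number, or whether the methyl and bromine attached to the rings play a part. They also leave open whether a small alkyl group such as methyl, or a ring carrying an amine or a carboxylic acid, could bring the number on this nitrogen below that of compound 2.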